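Swapping a substituted benzyl for furanylmethyl: expected solubility

The compounds below may be only part of what the source reports. "The series", "measured", "known", "first", "only" and "open" are said of these compounds alone.

Measured so far:
compound 1, `COc1ccccc1Oc1ccc2c(NCCCNCc3ccco3)ccnc2c1`, 14500 nM
compound 2, `Fc1ccc(-c2ccc3c(NCCCNCc4ccco4)ccnc3c2)cc1`, 32000 nM
compound 3, `COc1ccc(F)cc1CNCCCNc1ccnc2cc(Cc3ccccc3)ccc12`, 4200 nM

In a physicochemical assay for solubility, with a stated time of 18 h, at pH 7.4 (a higher number here means a more soluble compound, a lower number a less soluble compound), compound 3 stands lowest of the three, beneath compound 1 and further beneath compound 2. Compound 4, `c1ccc(Cc2ccc3c(NCCCNCc4ccco4)ccnc3c2)cc1`, differs from compound 3 in one place: furan-2-yl in place of 5-fluoro-2-methoxyphenyl on a saturated chain carbon bound to an amine nitrogen. Within the data shown here, the only measured step, a 2.2-fold higher number from compound 1 to compound 2 (0.34 log units; beyond the scatter), changes a different part of the shared core, so no measured step bears directly on this swap. Compounds 1 and 2, which both carry the furan-2-yl group, sit above compound 3, so a rise in this assay is expected, of the order of a 2.9-fold higher number from compound 3 to compound 4 (0.46 log units; beyond the scatter). Compound 4 is therefore estimated at 12000 nM, within a range of 5000 nM to 30000 nM.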

Compound 4, solubility: 4200 nM
For compound 4 the middle estimate is 2.9-fold (0.46 log units) above the measured one; the measured number lies below the stated range.
By their numbers in this assay, from the lowest: compounds 3 and 4 (each within the scatter of the next); then compound 1; then compound 2.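

With benzyl on the aromatic carbon, changing 5-fluoro-2-methoxybenzyl to (furan-2-yl)methyl gives no change at the digits printed from compound 3 to compound 4 (within the scatter) in this assay and so does not separate these two groups. With (furan-2-yl)methyl held fixed, the group on the aromatic carbon does separate the compounds: benzyl gives a 7.6-fold lower number from compound 2 to compound 4 (0.88 log units; beyond the scatter) in place of 4-fluorophenyl and a 3.5-fold lower number from compound 1 to compound 4 (0.54 log units; beyond the scatter) in place of 2-methoxyphenoxy. No measurement shown here explains these results. As far as these compounds go, whether the swap would also give no separation with 4-fluorophenyl or 2-methoxyphenoxy on the aromatic carbon remains open. So does the effect of a morpholine or a carboxylic acid on the saturated chain carbon.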